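The compounds below may be only part of what the source reports. "The series", "measured", "known", "first", "only" and "open" are said of these compounds alone.

Of the compounds shown here, three built on one shared core have been tested in an assay on isolated protein for inhibition of 3-hydroxy-3-methylglutaryl-coenzyme A reductase (Homo sapiens); on this read-out higher numbers stand for weaker inhibition and lower numbers for stronger inhibition. Compound 1 `CC(C)c1c(-c2ccc(F)cc2)nc(-c2ccc(F)cc2)n1/C=C/[C@@H](O)C[C@@H](O)CC(=O)O` gives 9 nM. Compound 2 `CC(C)c1nc(-c2ccc(F)cc2)c(-c2cc(Cl)cc(Cl)c2)n1/C=C/[C@@H](O)C[C@@H](O)CC(=O)O` gives 7.66 nM. Compound 3 `Cc1cc(C)cc(-c2c(-c3ccc(F)cc3)nc(C(C)C)n2/C=C/[C@@H](O)C[C@@H](O)CC(=O)O)c1` gives 7.25 nM. Of the three numbers, that of compound 3 is the smallest on paper, yet its gaps to compound 2 and to compound 1 both fall within the usual scatter, so the three compounds cannot really be separated on these data. Within the data shown here, the single step between measured compounds that differ in one place is a 1.1-fold lower number from compound 2 to compound 3 (0.02 log units; within the scatter), an exchange of one substituted phenyl ring for another on an aromatic carbon of the core.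

Compound 4 `Cc1cc(F)ccc1-c1c(-c2ccc(F)cc2)nc(C(C)C)n1/C=C/[C@@H](O)C[C@@H](O)CC(=O)O` differs from compound 3 by 4-fluoro-2-methylphenyl in place of 3,5-dimethylphenyl on an aromatic carbon. Among the measured compounds shown here, this is again an exchange of one substituted phenyl ring for another at the same place, and the one measured step of that kind stayed within the scatter. The step expected in this assay is therefore a 1.1-fold higher number from compound 3 to compound 4 (0.04 log units; within the scatter), with no movement beyond the scatter. Compound 4 is estimated to give about 8 nM, within a range from 4 nM to 16 nM.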

Compound 4, half-maximal inhibitory concentration: 8.4 nM
Compound 4: the middle estimate sits 1.1-fold (0.02 log units) below what was measured, within the range that was stated.
By their numbers in this assay, from the lowest: compounds 3, 2, 4 and 1 (each within the scatter of the next).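

In this assay, placing 4-fluoro-2-methylphenyl on this aromatic carbon of the core in place of 3,5-dimethylphenyl gives a 1.2-fold higher number from compound 3 to compound 4 (0.06 log units; within the scatter), and placing it there in place of 3,5-dichlorophenyl gives a 1.1-fold higher number from compound 2 to compound 4 (0.04 log units; within the scatter). Three differently substituted phenyl rings have now been compared at this position, and this assay cannot tell them apart, even though the new ring carries a fluorine and a methyl group rather than two identical substituents. Nothing available here explains why these rings read alike.

From the compounds shown here alone, all three compounds compared at this place carry a substituted phenyl ring, so it remains open how far this flat response extends. A plain phenyl, a pyridine or cyclohexyl ring, or a phenyl ring bearing an amine or a carboxylic acid could still shift the number.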